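Swapping the isoxazole side arm for an isopropylpyrazole

This account rests on a few compounds, and the source may have more. Where it says the series, first, only, none or still open, it means among the compounds named here.

Three compounds of one series share a core and differ in the group attached to the central five-membered ring. Compound 1 `CCNC(=O)c1noc(-c2cc(C(C)C)c(O)cc2O)c1-c1cc(COCC(=O)O)no1` and compound 2 `CCNC(=O)c1noc(-c2cc(C(C)C)c(O)cc2O)c1-c1cc(COCC(N)=O)no1` carry an acid and an amide on their side arm; in a functional assay on A2780 cells (Homo sapiens) for inhibition (on this read-out higher numbers stand for weaker inhibition and lower numbers for stronger inhibition), compound 1 gives "not determined" (no result reported) and compound 2 gives "not determined" (no result reported), so neither offers a number. Compound 3 `C=CNCc1cc(-c2c(C(=O)NCC)noc2-c2cc(C(C)C)c(O)cc2O)on1` is the only one with a result: in this assay compound 3 gives 43 nM, which places it alone at the head of the numbers shown, with nothing to compare against.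

Compound 4 `CCNC(=O)c1noc(-c2cc(C(C)C)c(O)cc2O)c1-c1ccn(C(C)C)n1` is yet to be tested. It differs from compound 3 at one position: 1-isopropyl-1H-pyrazol-3-yl in place of 3-((vinylamino)methyl)-1,2-oxazol-5-yl on an aromatic carbon. Going by the values given here, no measured pair shows how such a swap moves the read-out, so the expectation rests on compound 3 alone. Compound 4 is expected to come out near compound 3, with a step of a 1.4-fold higher number from compound 3 to compound 4 (0.14 log units; within the scatter) that stays within the usual scatter. The estimate for compound 4 in this assay is 60 nM, with a range from 15 nM to 250 nM.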

Compound 4, half-maximal inhibitory concentration: 45 nM
Compound 4: middle estimate off by 1.3-fold (0.12 log units), on the high side; low and high end bracket the measured number.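

In this assay the swap gives a 1.0-fold higher number from compound 3 to compound 4 (0.02 log units; within the scatter) and so shows that this position on the shared core can take a quite different side arm, with the two numbers within the usual scatter of each other. The 1-isopropyl-1H-pyrazol-3-yl group has 0 hydrogen-bond donors and no double bond outside aromatic rings, where 3-((vinylamino)methyl)-1,2-oxazol-5-yl has 1 donor and 1 such double bond, so in this pair neither feature is needed for a number of this size. No outside measurement bears on why the two compounds read alike.

Still open, as far as these compounds go, is whether a methyl group, or a longer chain such as n-butyl, on the pyrazole nitrogen would read like the isopropyl group. With no number for compound 1 or compound 2, the arms carrying an acid and an amide also cannot be set against the other two.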